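Inverting the ring stereocentre of compound 2

The compounds below may be only part of what the source reports. "The series", "measured", "known", "first", "only" and "open" are said of these compounds alone.

For the measured compounds named here, compound 2 `COc1ccc(Cl)cc1NC(=O)CN1CCN(S(=O)(=O)N2CCC(C)CC2)[C@H](C)C1` gives the highest of the two numbers so far in an assay on HEK293 cells for inhibition of potassium channel subfamily T member 1 (Homo sapiens), read by thallium flux (on this read-out lower numbers stand for stronger inhibition and higher numbers for weaker inhibition), at 13000 nM. Going by the values given here, its nearest neighbour, compound 1 `CCCOc1ccc(Cl)cc1NC(=O)CN1CCN(S(=O)(=O)N2CCC(C)CC2)CC1`, gives 4300 nM in this assay, a gap beyond the scatter, though no single-point step joins these two. Compound 3 `COc1ccc(Cl)cc1NC(=O)CN1CCN(S(=O)(=O)N2CCC(C)CC2)[C@@H](C)C1` is next for this assay. Change from compound 2 to compound 3: the two compounds have the same atoms and bonds and differ only in configuration as drawn: 1 of 1 stereo elements differ; a stereocentre at a saturated ring carbon is drawn R in compound 2 and S in compound 3. Among the compounds with values here, no measured pair shows a step of this kind, so the direction is open; a move beyond the scatter in either sense is plausible. Compound 3 is expected near 7000 nM, within 2000 nM to 30000 nM. The estimated step is a 1.9-fold lower number from compound 2 to compound 3 (0.27 log units; within the scatter).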

Compound 3, half-maximal inhibitory concentration: > 10000 nM
Compound 3: only a limit was reported; the forecaster's own chance of this, stated with the estimate: 10%; middle value at least 1.4-fold (0.15 log units) away from the limit.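

For the compounds shown here, for compound 3, this assay gives only a limit, > 10000 nM, so no step from compound 2 to compound 3 can be read. Going by these compounds, whether the S or the R configuration gives the lower number remains open.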